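The source may report more compounds than this note shows. Statements on the series, on what has been measured and on what is new or still open speak of the compounds shown alone.

Working notes on the series: in a functional assay on HL-60 cells (Homo sapiens) for inhibition, read by MTT assay, with a stated time of 72 h (a higher number here means a weaker inhibitor, a lower number a stronger inhibitor), compound 1 `Cc1ccc(C)c(N2CCN(C(=O)c3oc(C)nc3-c3ccc(F)cc3)CC2)c1` gives 358 nM and compound 3 `Cc1ccc(C)c(N2CCN(C(=O)c3oc(C)nc3-c3cccc(Cl)c3)CC2)c1` gives 345 nM, so the two sit level within the scatter. Compound 2 `Cc1ccc(C)c(N2CCN(C(=O)c3oc(C)nc3-c3ccccc3Cl)CC2)c1` reads > 1000 nM, which is a limit of the assay and not a number. The measured steps change only the chlorophenyl or fluorophenyl group: a 1.0-fold lower number from compound 1 to compound 3 (0.02 log units; within the scatter) stays within the scatter, while an at least 2.7-fold higher number from compound 1 to compound 2 (0.44 log units; beyond the scatter) goes beyond it. Compound 4 `COc1cccc(N2CCN(C(=O)c3oc(C)nc3-c3ccc(F)cc3)CC2)c1` changes a different place: 3-methoxyphenyl in place of 2,5-dimethylphenyl on an amine nitrogen in a ring. For the measured compounds named here, no measured step covers this place, so the expectation rests on compound 1 at 358 nM, and no step beyond the scatter is anticipated. The expected step is a 1.3-fold higher number from compound 1 to compound 4 (0.10 log units; within the scatter). For compound 4 the estimate is 450 nM, with an expected range of 150 nM to 1000 nM.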

Compound 4, half-maximal inhibitory concentration: 112 nM
Compound 4: middle estimate off by 4.0-fold (0.60 log units), on the high side, outside the stated range (below it).
By their numbers in this assay, from the lowest: compound 4; then compounds 3 and 1 (each within the scatter of the next). At a limit, above all of these: compound 2.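

For the compounds shown here, the step on the amine nitrogen in a ring gives a 3.2-fold lower number from compound 1 to compound 4 (0.50 log units; beyond the scatter) in this assay, so this place, which no earlier step touched, also moves the number. The entering 3-methoxyphenyl has 1 hydrogen-bond acceptor and the leaving 2,5-dimethylphenyl has 0, at 8 heavy atoms each, but nothing available ties the step to either group.

The compounds shown leave open whether the gain comes from the methoxy group or from the loss of the two methyl groups. Going by these compounds, a plain phenyl group on that nitrogen would help separate the two, and how an ethoxy group reads there also remains open.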